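Replacing Furan-2-yl with 3-Aminothiophen-2-yl at the Carbonyl

This account rests on a few compounds, and the source may have more. Where it says the series, first, only, none or still open, it means among the compounds named here.

Measured so far in a functional assay on NCI-H460 cells (Homo sapiens) for antiproliferative activity, read by XTT assay, with a stated time of 72 h; a higher number here means a weaker inhibitor, a lower number a stronger inhibitor:
Compound 1 `COc1ccc(-c2cc3ccccc3nc2/C=C/C(=O)c2ccc(F)cc2)cc1` gives 6990 nM.
Compound 2 `COc1ccc(-c2cc3ccccc3nc2/C=C/C(=O)c2ccc(O)cc2)cc1` gives 6930 nM.
Compound 3 `COc1ccc(-c2cc3ccccc3nc2/C=C/C(=O)c2ccco2)cc1` gives 6430 nM.

All three share one core and differ only in what sits on the carbonyl carbon or on its aromatic ring. Exchanging hydroxy for fluoro gave a 1.0-fold lower number from compound 1 to compound 2 (0.00 log units; within the scatter). Exchanging the whole ring on the carbonyl carbon gave a 1.1-fold lower number from compound 1 to compound 3 (0.04 log units; within the scatter) and a 1.1-fold lower number from compound 2 to compound 3 (0.03 log units; within the scatter). So compound 3 stands level with the other two; its number is not set apart from either.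

Compound 4 `COc1ccc(-c2cc3ccccc3nc2/C=C/C(=O)c2sccc2N)cc1` has not yet been measured. It differs from compound 3 by 3-aminothiophen-2-yl in place of furan-2-yl on a carbonyl carbon. Going by the values given here, the steps that bear on this are the two earlier exchanges at the same carbonyl carbon, and both lay within the scatter. With no shown case of this position moving the number beyond the scatter, the expected step is a 1.0-fold lower number from compound 3 to compound 4 (0.00 log units; within the scatter), that is, none beyond the scatter. Compound 4 is therefore estimated at 6400 nM in this assay, with a range from 3000 nM to 14000 nM.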

Compound 4, half-maximal inhibitory concentration: > 10000 nM
Compound 4: only a limit was reported (the forecaster's own chance of this, stated with the estimate: 5%); at least 1.5-fold (0.19 log units) between middle value and limit.
By their numbers in this assay, from the lowest: compounds 3, 2 and 1 (each within the scatter of the next). At a limit, above all of these: compound 4.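

Compound 4 is the first compound with a new ring on this carbonyl carbon to give a limit rather than a number: the limit of > 10000 nM in this assay, at which 1 of the 4 values shown sits.

With 3-aminothiophen-2-yl on the carbonyl carbon, the data give an at least 1.5-fold higher number from compound 3 to compound 4 (0.19 log units; that floor lies within the scatter), an at least 1.4-fold higher number from compound 2 to compound 4 (0.15 log units; that floor lies within the scatter) and an at least 1.4-fold higher number from compound 1 to compound 4 (0.15 log units; that floor lies within the scatter). Going by these compounds, these are floors only, so this exchange may have moved the number further than the earlier ring exchanges did, but the floors alone do not show that, and the true size of the step remains unknown.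

The compounds shown leave open whether the limit goes with the sulfur of the new ring or with its amine. A plain thiophen-2-yl and a furan-2-yl carrying an amine on the carbonyl carbon would pull these two changes apart.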